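A few compounds are considered here, and "the series" means these few. Any claim that something is new, unique, unknown or untested is made for them only; others in the source may bear on it.

Compounds measured in a functional assay on HCT-116 cells (Homo sapiens) for cytotoxicity, read by MTT assay, with a stated time of 72 h; on this read-out lower numbers stand for stronger inhibition and higher numbers for weaker inhibition:
- compound 1, `N[C@H]1CC[C@H](Nc2c(C(=O)NCc3ccccn3)nc(Br)c3cccnc23)CC1`: "not determined" (no result reported)
- compound 2, `N[C@H]1CC[C@H](Nc2c(C(=O)NCc3ccc(F)cc3)nc(Br)c3cccnc23)CC1`: 7000 nM
- compound 3, `COc1ccc(CNC(=O)c2nc(Br)c3cccnc3c2N[C@H]2CC[C@H](N)CC2)cc1`: 3000 nM

Compound 3 stands at the lowest number of the two that were obtained; its nearest neighbour is compound 2, and the step of a 2.3-fold lower number from compound 2 to compound 3 (0.37 log units; beyond the scatter) separates them, with methoxy in place of fluoro on an aromatic carbon. Compound 1 carries no result in this assay.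

Compound 4, `C[C@H](NC(=O)c1nc(Br)c2cccnc2c1N[C@H]1CC[C@H](N)CC1)c1ccc(F)cc1`, differs from compound 3 by 1-(4-fluorophenyl)ethyl in place of 4-methoxybenzyl on an amide-type nitrogen. Among the compounds with values here, only one measured step bears on this change, and only in part: the step of a 2.3-fold lower number from compound 2 to compound 3 (0.37 log units; beyond the scatter) shows that exchanging fluoro for methoxy on that aromatic carbon moved the number modestly downward, so the reverse exchange, as in compound 4, is expected to move it back upward by a similar amount. Within the data shown here, the added methyl on the carbon next to the amide-type nitrogen, with its defined stereocentre, has no counterpart among the measured compounds, and its effect cannot be read from these data. Compound 4 is therefore expected to show a step of a 2.3-fold higher number from compound 3 to compound 4 (0.37 log units; beyond the scatter), giving an estimate of 7000 nM, within a range of 2500 nM to 20000 nM.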

Compound 4, half-maximal inhibitory concentration: > 10000 nM
Compound 4 was reported as a limit; the forecaster's own chance of this, stated with the estimate: 10%; middle value at least 1.4-fold (0.15 log units) away from the limit.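

Within the data shown here, compound 4 sits at a limit of the assay, not at a number: the limit of > 10000 nM in this assay, at which 1 of the 4 values shown sits. Replacing 4-methoxybenzyl with 1-(4-fluorophenyl)ethyl on the amide-type nitrogen gives an at least 3.3-fold higher number from compound 3 to compound 4 (0.52 log units; beyond the scatter), a larger move than the earlier compounds showed at this position in this assay. The methyl on the saturated chain carbon, the first change shown at that carbon, gives an at least 1.4-fold higher number from compound 2 to compound 4 (0.15 log units; that floor lies within the scatter), so it brought no lower number, but this floor alone does not establish a real rise.

From the compounds shown here alone, how far compound 4 lies past its limit stays open, as does whether the opposite configuration at the stereocentre would read differently. Also open, going by these compounds, is how an ethyl or a hydroxymethyl on that carbon, or a methoxy in place of the fluoro in compound 4, would behave.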